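This account rests on a few compounds, and the source may have more. Where it says the series, first, only, none or still open, it means among the compounds named here.

Measured compounds:
- compound 1, `COc1ccc2[nH]c(C(=O)N3CC(=O)N(Cc4ccccc4)[C@@H](CN4CCCCC4)C3)cc2c1`. In a physicochemical assay for solubility, read by spectrophotometry, in phosphate buffer, with a stated time of 2 h, at pH 7.4 (a higher number here means a more soluble compound, a lower number a less soluble compound), compound 1 gives > 25000 nM, which is a limit of the assay and not a number.
- compound 2, `COc1ccc2[nH]c(C(=O)N3CC(=O)N(Cc4ccccc4)[C@@H](CCN4CCC5(CC4)CC5)C3)cc2c1`. In this assay compound 2 gives > 25000 nM, which is likewise a limit of the assay.

Compound 2 therefore stands at the upper edge of what this assay reports, and compound 1 stands at the same edge, the two values sitting at the limit of > 25000 nM in this assay, at which 2 of the 2 values shown sit. Among the measured compounds shown here, the only step between measured compounds, a step that the two limits leave unreadable from compound 1 to compound 2, cannot be read in size or direction from those two limits.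

Compound 3, `COc1ccc2[nH]c(C(=O)N3CC(=O)N(Cc4ccccc4)[C@@H](N4CCc5ccccc54)C3)cc2c1`, differs from compound 2 by a group of 9 heavy atoms (8 carbon, 1 nitrogen; one five-membered non-aromatic ring with 1 hetero atom, one six-membered aromatic ring of carbon only) in place of a group of 10 heavy atoms (9 carbon, 1 nitrogen; one three-membered non-aromatic ring of carbon only, one six-membered non-aromatic ring with 1 hetero atom), on a saturated ring carbon. For the measured compounds named here, no measured step bears on this change in a readable way, and the data give no direction for it beyond the scatter. Because the limit of > 25000 nM in this assay, at which 2 of the 2 values shown sit, holds for both measured compounds, compound 3 is expected to sit in the same region of this assay. The estimate for compound 3 in this assay is 30000 nM, with an expected range from 10000 nM to 90000 nM. This estimate means a step that the limit leaves unreadable from compound 2 to compound 3, which is expected to stay within the scatter.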

Compound 3, solubility: 7000 nM
Compound 3: middle estimate off by 4.3-fold (0.63 log units), on the high side; measured number below the stated range.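

Among the compounds shown here, at the saturated ring carbon that carries the changing group, the earlier pair showed nothing, since its only step cannot be read. In this assay, 2,3-dihydro-1H-indol-1-yl in place of the group with the three-membered ring gives an at least 3.5-fold lower number from compound 2 to compound 3 (0.55 log units; beyond the scatter), and in place of (piperidin-1-yl)methyl it gives an at least 3.5-fold lower number from compound 1 to compound 3 (0.55 log units; beyond the scatter), so the group at this position can bring a compound off the upper edge of the scale. Both steps give only a smallest size, since the starting values of compound 1 and compound 2 are limits and not numbers, and the full size of the drop stays unknown: the limit of > 25000 nM in this assay, at which 2 of the 3 values shown sit.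

The compounds shown leave open whether the lower number goes with the six-membered aromatic ring or with the nitrogen standing directly on the ring carbon, since the two differ together between these compounds. On these data alone, a piperidin-1-yl group set directly on this carbon, or a (2,3-dihydro-1H-indol-1-yl)methyl group, would separate the two, and how a carboxylic acid would read at this position also remains open.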